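Trimming an ethyl to methyl in a cytochrome P450 11B1 series

The source may hold more compounds than are shown below. What is called first, only, known or untested is meant among the compounds shown, and "the series" means these compounds.

Measured compounds:
compound 1 `CC(=O)N[C@@H]1CCCc2c1cncc2N1CCc2cc(Cl)ccc2C1=O` 3920 nM
compound 2 `CCC(=O)N[C@@H]1CCCc2c1cncc2N1CCc2cc(Cl)ccc2C1=O` 3330 nM
compound 3 `CCC(=O)N[C@@H]1CCCc2c1cncc2N1C(=O)c2ccc(Cl)cc2[C@H]1CC` 10200 nM

Of the compounds shown here, three have been measured in an ADME assay on cells for inhibition of cytochrome P450 11B1, mitochondrial (Homo sapiens), read by HTRF (on this read-out lower numbers stand for stronger inhibition and higher numbers for weaker inhibition), and a fourth awaits measurement. Compound 1 and compound 2 share a core and differ only in the amide chain: hydrogen in place of methyl on a saturated chain carbon bound to a carbonyl carbon. That step, a 1.2-fold higher number from compound 2 to compound 1 (0.07 log units; within the scatter), falls within the scatter, so the two values cannot be ordered. Compound 3 carries the same propanoyl amide as compound 2 but a different core; the difference between the two cores is not broken down here. Compound 3 gives the highest of the three numbers, standing beyond the scatter from both compound 1 and compound 2.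

Compound 4 `CCC(=O)N[C@@H]1CCCc2c1cncc2N1C(=O)c2ccc(Cl)cc2[C@H]1C` is compound 3 with one change: hydrogen in place of methyl on a saturated chain carbon bound to a saturated ring carbon. Among the compounds with values here, this is the same kind of change as the one from compound 2 to compound 1, but not the same, since there the carbon sits bound to a carbonyl carbon, while here it sits bound to a saturated ring carbon. Within the data shown here, as the only measured example of this kind of change, a 1.2-fold higher number from compound 2 to compound 1 (0.07 log units; within the scatter), is within the scatter, compound 4 is expected to stay close to compound 3, with a step of about a 1.1-fold lower number from compound 3 to compound 4 (0.03 log units; within the scatter). The estimate for compound 4 is therefore 9500 nM, expected to lie between 4500 nM and 20000 nM, resting on the value of compound 3, 10200 nM, and on the small step seen between compound 2 and compound 1.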

Compound 4, half-maximal inhibitory concentration: 9410 nM
Compound 4: the middle estimate sits 1.0-fold (0.00 log units) above what was measured, within the range that was stated.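

In this assay the change from ethyl to methyl on the core of compound 3 gave a 1.1-fold lower number from compound 3 to compound 4 (0.04 log units; within the scatter). Set beside the earlier removal of a methyl from the amide chain, on the core of compound 1, this step does not differ from it beyond the scatter: the same change on two cores in this assay, a 1.2-fold higher number (0.07 log units; within the scatter) from compound 2 to compound 1 and a 1.1-fold lower number (0.04 log units; within the scatter) from compound 3 to compound 4, 1.3-fold (0.11 log units) apart, within the scatter of two such steps This shows that in both pairs a hydrogen in place of a methyl left the read-out within the scatter, but it does not show that the change would behave alike on further cores, and it is no true test of transfer, since on one core the methyl sits on a saturated chain carbon bound to a carbonyl carbon and on the other on a saturated chain carbon bound to a saturated ring carbon.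

The compounds shown leave open what a longer chain, an amine or a carboxylic acid would give on the saturated ring carbon that carries the ethyl in compound 3 and the methyl in compound 4. Within the data shown here, they also leave open whether a larger change on the amide chain than the one between compound 2 and compound 1 would give a step beyond the scatter.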